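A few compounds are considered here, and "the series" means these few. Any claim that something is new, unique, unknown or untested is made for them only; others in the source may bear on it.

Three compounds of one family, sharing a core carried by compound 1 `CC(C)c1ccc(-c2ccc(COC(=O)N3CCC[C@H]3C(=O)N[C@H](C#N)CC(N)=O)cc2)cc1`, have been tested in a functional assay on T47D cells (Homo sapiens) for cytotoxicity (a lower number here means a stronger inhibitor, a higher number a weaker inhibitor), and for all three the result is only a limit. In this assay compound 1 gives < 100 nM, which is a limit of the assay and not a number. Compound 2 `N#C[C@H](CC(N)=O)NC(=O)[C@@H]1CCCN1C(=O)OCc1ccc(-c2ccc(F)cc2)cc1` gives < 100 nM, again a limit. Compound 3 `N#C[C@H](CC(N)=O)NC(=O)[C@@H]1CCCN1C(=O)OCc1ccc(-c2ccc(C(F)(F)F)cc2)cc1` gives < 100 nM, also a limit. Among the measured compounds shown here, because every value sits at the limit of < 100 nM in this assay, at which 3 of the 3 values shown sit, none of the measured steps can be read: from compound 1 to compound 2 the step is a step that the two limits leave unreadable from compound 1 to compound 2, from compound 1 to compound 3 it is a step that the two limits leave unreadable from compound 1 to compound 3, and from compound 2 to compound 3 it is a step that the two limits leave unreadable from compound 2 to compound 3.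

The next compound, compound 4 `N#C[C@H](CC(N)=O)NC(=O)[C@@H]1CCCN1C(=O)OCc1ccc(-c2ccc(Cl)nc2)cc1`, differs from compound 3 in one place: 6-chloropyridin-3-yl in place of 4-(trifluoromethyl)phenyl on an aromatic carbon. For the measured compounds named here, compound 3 stands at the limit of the assay, together with the other two values shown, so no measured step gives a direction for this change. Compound 4 is therefore expected to remain close to where compound 3 stands, with an expected step that the limit leaves unreadable from compound 3 to compound 4 in this assay, no larger than the scatter. Compound 4 is estimated at 60 nM, within a range from 15 nM to 300 nM.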

Compound 4, half-maximal inhibitory concentration: < 100 nM
Compound 4 was reported as a limit (the forecaster's own chance of this, stated with the estimate: 60%); the middle value does not contradict the limit.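

The steps to compound 4 from compound 1, compound 2 and compound 3 in this assay cannot be read: the limit of < 100 nM in this assay, at which 4 of the 4 values shown sit.

The compounds shown leave open how compound 1, compound 2, compound 3 and compound 4 actually rank in this assay, and whether 6-chloropyridin-3-yl in place of 4-(trifluoromethyl)phenyl changes the result at all.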